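The source may hold more compounds than are shown below. What is called first, only, known or untested is meant among the compounds shown, and "the series" means these compounds.

Values in a functional assay on DU-145 cells (Homo sapiens) for inhibition, read by trypan blue exclusion, with a stated time of 96 h (a lower number here means a stronger inhibitor of growth, a higher number a weaker inhibitor of growth), for the measured members of the series:

compound 1 `Cc1ccc(S(=O)(=O)/C(=C/c2ccc(O)c([N+](=O)[O-])c2)C(=O)c2ccc(Cl)cc2)cc1`: 25000 nM
compound 2 `Cc1ccc(CS(=O)(=O)/C(=C/c2cccc(Cl)c2Cl)C(=O)c2ccc(Cl)cc2)cc1`: 1000 nM
compound 3 `Cc1ccc(S/C(=C/c2c[nH]c3ccc(Cl)cc23)C(=O)c2ccc(Cl)cc2)cc1`: 1000 nM

Compound 2 and compound 3 are level at the digits shown, and together they give the lowest numbers of the three; compound 1 sits well beyond the scatter from compound 2, with a clearly higher number.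

Compound 4 `Cc1ccc(CS(=O)(=O)/C(=C/c2cc(C)ccc2C)C(=O)c2ccc(Cl)cc2)cc1` is not yet measured. It differs from compound 2 in one place: 2,5-dimethylphenyl in place of 2,3-dichlorophenyl on a double-bonded chain carbon bound to a double-bonded chain carbon. Among the measured compounds shown here, no measured pair isolates this kind of change, so nothing here fixes its size. The working expectation is a step of a 1.5-fold higher number from compound 2 to compound 4 (0.18 log units; within the scatter) in this assay, that is, no change beyond the scatter or a slight rise in the number. Compound 4 is therefore estimated at 1500 nM, within 500 nM to 5000 nM.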

Compound 4, concentration for 50% growth inhibition: 1000 nM
Beside the measured number, compound 4's estimate is 1.5-fold (0.18 log units) above it; the measured number falls inside the stated range.
By their numbers in this assay, from the lowest: compounds 2, 3 and 4 (each within the scatter of the next); then compound 1.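

In this assay, among the compounds shown here, 2,5-dimethylphenyl in place of 2,3-dichlorophenyl gives no change at the digits printed from compound 2 to compound 4 (within the scatter) and is the first step between compounds that differ in one place. At this position, on a double-bonded chain carbon bound to a double-bonded chain carbon, the two chlorine atoms of compound 2 can therefore give way to the two methyl groups of compound 4 without a change beyond the scatter. No supporting data account for this result.

Open, from the compounds shown here alone, is how an unsubstituted phenyl, or a ring carrying an amine or a carboxylic acid, would read at this position. Also open, going by these compounds, is whether the same exchange holds on the cores of compound 1 and compound 3.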